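Aryl swap at the exocyclic alkene of compound 2

The compounds below may be only part of what the source reports. "The series", "measured", "known", "first", "only" and "open" are said of these compounds alone.

Three compounds of this series have been run in a functional assay on HepG2 cells (Homo sapiens) for antiproliferative activity, read by MTT assay; on this read-out lower numbers stand for stronger inhibition and higher numbers for weaker inhibition. Compound 1 `O=C1N=C(N2CCC[C@H]2C(=O)Nc2ccc3ncnc(Nc4cccc(Cl)c4)c3c2)S/C1=C/c1cccc(Cl)c1` gives 27600 nM. Compound 2 `O=C1N=C(N2CCC[C@H]2C(=O)Nc2ccc3ncnc(Nc4cccc(Cl)c4)c3c2)S/C1=C/c1ccccc1Cl` gives 28100 nM, the highest of the three numbers; its nearest neighbour is compound 1, with a 1.0-fold higher number from compound 1 to compound 2 (0.01 log units; within the scatter), and its furthest is compound 3 `O=C1N=C(N2CCC[C@H]2C(=O)Nc2ccc3ncnc(Nc4cccc(Cl)c4)c3c2)S/C1=C/c1cccnc1`, which gives 8500 nM. The move to the pyridin-3-yl group shows up twice, as a 3.2-fold lower number from compound 1 to compound 3 (0.51 log units; beyond the scatter) and as a 3.3-fold lower number from compound 2 to compound 3 (0.52 log units; beyond the scatter), both modest and beyond the scatter, whereas the move between the two chlorophenyl isomers stays within the scatter.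

Compound 4 `O=C1N=C(N2CCC[C@H]2C(=O)Nc2ccc3ncnc(Nc4cccc(Cl)c4)c3c2)S/C1=C/c1cccs1` has not yet been measured. Its change from compound 2 is thiophen-2-yl in place of 2-chlorophenyl on a double-bonded chain carbon bound to a double-bonded ring carbon. Among the compounds with values here, no measured step introduces the thiophen-2-yl group, so the only guide is the replacement of a chlorophenyl ring by a heteroaromatic ring at the same place, which lowered the number modestly in the steps from compounds 1 and 2 to compound 3. A step of similar direction but less certain size is therefore expected, estimated as a 1.9-fold lower number from compound 2 to compound 4 (0.27 log units; within the scatter). On that basis compound 4 is expected to give about 15000 nM, within a range from 6000 nM to 40000 nM.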

Compound 4, half-maximal inhibitory concentration: 4120 nM
Estimate against measurement, compound 4: 3.6-fold (0.56 log units) above; measured number outside the range, below it.
By their numbers in this assay, from the lowest: compound 4; then compound 3; then compounds 1 and 2 (each within the scatter of the next).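

At this position, on a double-bonded chain carbon bound to a double-bonded ring carbon, in this assay, a five-membered aromatic ring with one hetero atom is accepted and gives the lowest number of the set, with a 6.8-fold lower number from compound 2 to compound 4 (0.83 log units; beyond the scatter) and a 6.7-fold lower number from compound 1 to compound 4 (0.83 log units; beyond the scatter). The two heteroaromatic rings are not interchangeable, as thiophen-2-yl and pyridin-3-yl are separated by a 2.1-fold lower number from compound 3 to compound 4 (0.31 log units; beyond the scatter), so the effect of leaving a chlorophenyl ring depends on which ring enters and is not a single shift shared by every heteroaromatic replacement. Nothing available bears on why the thiophen-2-yl ring gives this result.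

The change from 2-chlorophenyl to thiophen-2-yl alters ring size and introduces sulfur in one step, so the compounds shown cannot separate these two differences; furan-2-yl and unsubstituted phenyl would address that question directly. From the compounds shown here alone, it also remains open whether the thiophene ring can carry further groups at this position, such as a methyl group or an amine, without losing the lower number in this antiproliferative read-out.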